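Shortening a Chain While Hexokinase-2 Inhibition Stays Flat

This account rests on a few compounds, and the source may have more. Where it says the series, first, only, none or still open, it means among the compounds named here.

compound 1 `O=C(CI)NCCCCC(=O)NCCCCCCNc1ncnc2c1ncn2[C@@H]1O[C@H](COP(=O)(O)OP(=O)(O)OP(=O)(O)O)[C@@H](O)[C@H]1O` — 0%
compound 2 `CN(CCCCN(C)c1ncnc2c1ncn2[C@@H]1O[C@H](COP(=O)(O)OP(=O)(O)OP(=O)(O)O)[C@@H](O)[C@H]1O)C(=O)CCCCCNC(=O)CI` — 0%

In an assay on isolated protein for inhibition of hexokinase-2 (Rattus norvegicus), with a stated time of 6 h, tested at 10 mM (a higher number here means more inhibition at the concentration tested (going by the name of the read-out), a lower number less inhibition), compound 1 gives 0%, and compound 2 gives 0%. Among the measured compounds shown here, the two stand level within the scatter, so neither can be placed above the other, and no step between measured compounds is available to calibrate a change. Compound 3 `O=C(I)NCC(=O)NCCCCCCNc1ncnc2c1ncn2[C@@H]1O[C@H](COP(=O)(O)OP(=O)(O)OP(=O)(O)O)[C@@H](O)[C@H]1O` differs from compound 1 by a group of 4 heavy atoms (1 carbon, 1 nitrogen, 1 oxygen, 1 iodine; no ring) in place of a group of 8 heavy atoms (5 carbon, 1 nitrogen, 1 oxygen, 1 iodine; no ring), on a saturated chain carbon bound to a carbonyl carbon. Since compound 1 shows 0% and compound 2 likewise 0%, the expected step is a number 2 percentage points higher from compound 1 to compound 3 (within the scatter), that is none beyond the scatter. Compound 3 is therefore estimated at 2%, with a range from 0% to 12%.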

Compound 3, a percentage reported as inhibition, at one concentration (the size of the read-out at that concentration, not a potency): 0%
The estimate for compound 3 lay 2 percentage points above the measured number; the range from low to high includes it.
By their numbers in this assay, from the lowest: compounds 1, 2 and 3 (each within the scatter of the next).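

In this assay the read-out shows no change at the digits printed from compound 1 to compound 3 (within the scatter) when the 3-(((iodomethyl)carbonyl)amino)propyl group, on a saturated chain carbon bound to a carbonyl carbon, gives way to the group of 4 heavy atoms. Among the compounds shown here, this is the first step read at this position, and with no inhibition at either end it gives no sign that this change matters here. No supporting measurement bears on this result. The compounds shown leave open whether a longer chain, or an amine or a carboxylic acid at this place, would give any inhibition at all.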